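The source may hold more compounds than are shown below. What is called first, only, known or untested is meant among the compounds shown, and "the series" means these compounds.

Compound 1, `O/N=C(\CCN1CCN(c2ccccn2)CC1)c1cccc(Cl)c1`, gives 73% in a functional assay on HEK293 cells with D(4) dopamine receptor (Homo sapiens) as the target, read by FLIPR; on this read-out lower numbers stand for smaller maximal responses and higher numbers for larger maximal responses. Compound 2, `O/N=C(\CCN1CCN(c2ccccn2)CC1)c1cc(F)cc(F)c1`, gives 74% in this assay.

These two compounds share the same core and differ only in the ring attached to the carbon with a double bond to nitrogen. Compound 2 stands alongside compound 1 on the largest response reached: the step of a number 1 percentage points higher from compound 1 to compound 2 (within the scatter) is within the usual scatter, so the two values cannot be told apart.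

Compound 3, `Cc1ccc(O)c(/C(CCN2CCN(c3ccccn3)CC2)=N/O)c1`, has not yet been tested. It differs from compound 2 in that same place: 2-hydroxy-5-methylphenyl in place of 3,5-difluorophenyl on a carbon with a double bond to nitrogen. Among the compounds with values here, the one measured step that bears on this change is the swap of rings at this position from compound 1 to compound 2, and that swap left the response unchanged within the scatter. Within the data shown here, the new ring brings a hydrogen-bond donor and acceptor that neither earlier ring carried, so the single earlier step is only a loose guide. Compound 3 is therefore expected to respond much like compound 2, with a step of about a number 4 percentage points lower from compound 2 to compound 3 (within the scatter), and an estimated value of 70%, between 50% and 85%.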

Compound 3, largest response reached (reported as efficacy), in percent of the reference or control that the assay uses: 73%
Compound 3: the middle estimate sits 3 percentage points below what was measured; the range from low to high includes it.
By their numbers in this assay, from the lowest: compounds 1, 3 and 2 (each within the scatter of the next).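

Within the data shown here, the earlier pair showed only that one halogen-carrying ring could stand in for another on the carbon with a double bond to nitrogen, whereas 2-hydroxy-5-methylphenyl has no halogen and carries a hydrogen-bond donor and acceptor that 3,5-difluorophenyl lacks. Even so, this assay gives a step of a number 1 percentage points lower from compound 2 to compound 3 (within the scatter) and a step of no change at the digits printed from compound 1 to compound 3 (within the scatter) for this ring, so on the largest response reached the three compounds cannot be told apart, and this position has now accepted a far more different ring with no visible change in the number. No measurement at hand explains why the response stays level across these rings.

All three rings shown are six-membered aromatic rings of carbon only, so it remains open whether an amine or a carboxylic acid on the ring, or a longer chain in its place, would shift the response. The hydroxy and methyl groups also enter together in compound 3, which leaves what each one contributes alone unresolved.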